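Ethyl in place of hydrogen on the pyridine-bearing benzimidazole core

This account rests on a few compounds, and the source may have more. Where it says the series, first, only, none or still open, it means among the compounds named here.

Measured so far:
Compound 1, `CCc1cccc(-c2nc3cc(OC)ccc3[nH]2)n1`: 52%
Compound 2, `COC(=O)Cn1c(-c2ccccn2)nc2ccccc21`: -17%
Compound 3, `Cc1ccc(-c2nc3ccccc3n2CC(=O)N2CCCCC2)nc1`: 2%

Of the compounds shown here, three that share a core have been tested in a functional assay on the whole organism with Rattus norvegicus as the target, read by paw edema, with a stated time of 3 h, at a dose of 100 mg/kg by the oral route; a lower number here means less inhibition, a higher number more inhibition at the dose given (going by the name of the read-out). Compound 1 gives 52% in this assay, the highest of the three numbers. Compound 3 gives 2% in this assay. Compound 2 stands lowest in this assay with -17%; the nearest number, that of compound 3, lies beyond the scatter above it, and the number of compound 1 lies further above it still. For the measured compounds named here, no two of the three compounds differ in a single place, so no single step between measured compounds can be read off.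

The next compound, compound 4, `CCc1ccc(-c2nc3ccccc3n2CC(=O)OC)nc1`, differs from compound 2 in one place: ethyl in place of hydrogen on an aromatic carbon. Compound 1 carries an ethyl group and reaches the highest number, while compound 3 carries a methyl on the same kind of ring and stays near the low end, so the three measured compounds give no clear direction for this change. For compound 4 a step of modest size upward from the lowest number is expected, a number 22 percentage points higher from compound 2 to compound 4 (beyond the scatter), but it may well remain within the scatter. Compound 4 is therefore estimated at 5% in this assay, with a range from -20% to 30%.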

Compound 4, a percentage reported as inhibition, in the whole organism at one dose (the size of the read-out at that dose, not a potency): 9%
For compound 4 the middle estimate is 4 percentage points below the measured one, and the stated range covers the measured number.
By their numbers in this assay, from the lowest: compound 2; then compounds 3 and 4 (each within the scatter of the next); then compound 1.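

In this assay, for the compounds shown here, ethyl in place of hydrogen gives a number 26 percentage points higher from compound 2 to compound 4 (beyond the scatter), the first step in this set that can be read from a single change, and it places a number on this position: on an aromatic carbon of a six-membered aromatic ring with 1 nitrogen, two atoms from the ring nitrogen, para to a large group. Going by these compounds alone, the step is modest but lies beyond the scatter, taking the pair from compound 2 at -17% to compound 4 at 9%, so at this position the change goes upward, which the earlier compounds could not show. Nothing available explains why the number rises with this change.

Going by these compounds, what remains open is whether a longer chain such as propyl, or an amine or a carboxylic acid at the same place, would carry the number further, hold it or reverse it. This single pair also leaves open whether ethyl gives a step of similar size on compounds that do not carry the methyl ester side chain of compound 2 and compound 4.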